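A few compounds are considered here, and "the series" means these few. Any claim that something is new, unique, unknown or untested is made for them only; others in the source may bear on it.

Measured in a physicochemical assay for acid dissociation:

- compound 1 `COc1ccc(CN(CCN(C)C)c2ccc(Cl)cc2)cc1`: 9.6
- compound 2 `COc1ccc(CN(CCN(C)C)c2ccc(C)cc2)cc1`: 9.8

Among the measured compounds shown here, compound 2 stands at 9.8, and the only other number available cannot be told apart from it. For the measured compounds named here, the single measured step is a number 0.20 log units higher from compound 1 to compound 2 (within the scatter), for methyl in place of chloro on an aromatic carbon.

Compound 3 `COc1ccc(CN(CCN(C)C)c2ccc(N)cn2)cc1` goes further than that step, with 5-aminopyridin-2-yl in place of 4-methylphenyl on an amine nitrogen. This exchanges the whole aromatic ring and its substituent, whereas the measured step exchanged one substituent on an unchanged ring. Going by the values given here, no measured compound carries a ring with a hetero atom, so the step from compound 1 to compound 2 bears on this change only loosely. It shows a single substituent exchange with no effect beyond the scatter, and it gives no direction for the new change.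

A modest move is therefore expected, tentatively downward and not far beyond the scatter, with a wide margin. The estimated step is a number 0.40 log units lower from compound 2 to compound 3 (beyond the scatter). For compound 3 the expected value is 9.4, with an estimated range from 8.9 to 9.8.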

Compound 3, acid dissociation constant: 9.4
Estimate against measurement, compound 3: no gap at the digits printed, and the stated range covers the measured number.
By their numbers in this assay, from the lowest: compounds 3, 1 and 2 (each within the scatter of the next, the first and the last beyond it).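

In this assay, among the compounds shown here, the exchange of the whole aromatic group on the amine nitrogen, 5-aminopyridin-2-yl in place of 4-methylphenyl, gives a number 0.40 log units lower from compound 2 to compound 3 (beyond the scatter) and is the first change at this position to pass beyond the scatter, which the single substituent exchange on an unchanged ring did not do. The result depends on the compound it is set against: 5-aminopyridin-2-yl in place of 4-chlorophenyl gives a number 0.20 log units lower from compound 1 to compound 3 (within the scatter), so the same entering group separates from one neighbour and not from the other, and the whole change remains modest in size. Nothing available here explains why the number moves in this way.

In compound 3 the ring with a hetero atom and the amine on it enter together, so the compounds shown do not tell how much of the step belongs to either part. A compound with a plain pyridin-2-yl group and one with a 4-aminophenyl group on the same amine nitrogen would each carry only one of these two parts and could separate them.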